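Anilino variation on the shared core: para-methoxy replaces sulfamoyl

A few compounds are considered here, and "the series" means these few. Any claim that something is new, unique, unknown or untested is made for them only; others in the source may bear on it.

Compound 1 `Cc1cc(Nc2cc(N3CCN(C)CC3)nc(Nc3ccc(S(N)(=O)=O)cc3)n2)n[nH]1` gives 1430 nM in a functional assay on K562 cells (Homo sapiens) for antiproliferative activity, read by CCK-8 assay, with a stated time of 72 h (on this read-out lower numbers stand for stronger inhibition and higher numbers for weaker inhibition), and stands highest of the three numbers measured; compound 2 `COc1cccc(Nc2nc(Nc3cc(C)[nH]n3)cc(N3CCN(C)CC3)n2)c1` gives 509 nM and compound 3 `Cc1cc(Nc2cc(N3CCN(C)CC3)nc(Nc3cccc([N+](=O)[O-])c3)n2)n[nH]1` gives 138 nM. Compound 4 `COc1ccc(Nc2nc(Nc3cc(C)[nH]n3)cc(N3CCN(C)CC3)n2)cc1` differs from compound 1 as follows: methoxy in place of sulfamoyl on an aromatic carbon. The step that bears most directly on it is a 2.8-fold lower number from compound 1 to compound 2 (0.45 log units; beyond the scatter), where a methoxy group likewise replaced the sulfamoyl group, though at a different place on the ring. The larger step of a 10-fold lower number from compound 1 to compound 3 (1.02 log units; beyond the scatter) involved a nitro group and is less comparable. A modest step downward is therefore expected for compound 4, roughly a 2.4-fold lower number from compound 1 to compound 4 (0.38 log units; beyond the scatter), with an estimated value of 600 nM and a range of 250 nM to 1500 nM.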

Compound 4, half-maximal inhibitory concentration: 271 nM
For compound 4 the middle estimate is 2.2-fold (0.35 log units) above the measured one; the range from low to high includes it.
By their numbers in this assay, from the lowest: compounds 3, 4 and 2 (each within the scatter of the next, the first and the last beyond it); then compound 1.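

In this assay, methoxy in place of sulfamoyl on the aromatic carbon para to a large group gives a 5.3-fold lower number from compound 1 to compound 4 (0.72 log units; beyond the scatter) in this series, a larger step than the one seen for the 3-methoxyphenyl compound. The two methoxy placements are not separated, since a 1.9-fold lower number from compound 2 to compound 4 (0.27 log units; within the scatter) lies within the scatter. The 4-methoxyphenyl and 3-nitrophenyl compounds are not separated either, with a 2.0-fold higher number from compound 3 to compound 4 (0.29 log units; within the scatter) also within the scatter.

As far as these compounds go, whether an amine or a carboxylic acid at this place would fall with methoxy or with sulfamoyl remains open. No measured evidence accounts for these steps.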